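A Third Placement of Chloro on the Aromatic Ring

A few compounds are considered here, and "the series" means these few. Any claim that something is new, unique, unknown or untested is made for them only; others in the source may bear on it.

In an assay on CHO-K1 cells for displacement of a labelled ligand from Neuronal acetylcholine receptor; alpha4/beta2 (Homo sapiens), read by scintillation counting (on this read-out lower numbers stand for stronger inhibition and higher numbers for weaker inhibition), compound 2 `C[C@@]12C[C@@H]1CC(COc1cccnc1)N2` gives 3.6 nM, the lowest of the two numbers in hand. Compound 3 `C[C@@]12C[C@@H]1CC(COc1ccc(Cl)nc1)N2` gives 6880 nM in this assay. Compound 1 `C[C@@]12C[C@@H]1CC(COc1cccnc1Cl)N2` reports > 10000 nM, which is a limit of this assay and not a number. Compound 4 `C[C@@]12C[C@@H]1CC(COc1cncc(Cl)c1)N2` differs from compound 2 by chloro in place of hydrogen on an aromatic carbon. Both measured steps bear on this change: an at least 2700-fold lower number from compound 1 to compound 2 (3.44 log units; beyond the scatter) and a 1900-fold higher number from compound 2 to compound 3 (3.28 log units; beyond the scatter), each showing that a chloro on this ring sits far beyond the scatter from the unsubstituted compound 2. The author therefore expects a large rise in this assay, a 560-fold higher number from compound 2 to compound 4 (2.74 log units; beyond the scatter). Compound 4 is estimated at 2000 nM, within a range from 200 nM to 20000 nM.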

Compound 4, inhibition constant: 577 nM
For compound 4 the middle estimate is 3.5-fold (0.54 log units) above the measured one, within the range that was stated.
By their numbers in this assay, from the lowest: compound 2; then compound 4; then compound 3. At a limit, above all of these: compound 1.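

At this third position, two atoms from the ring nitrogen, chloro also brings a large change in this assay, with a 160-fold higher number from compound 2 to compound 4 (2.20 log units; beyond the scatter). No chloro placement shown comes near compound 2, although compound 4 has the lowest number among the chloro compounds with a measured value. Nothing measured here bears on why chloro has this effect at this position.

From the compounds shown here alone, whether fluoro, methyl or an amine at this position would stay closer to compound 2 remains open. So does whether a methoxy group would behave as chloro does.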